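A few compounds are considered here, and "the series" means these few. Any claim that something is new, unique, unknown or untested is made for them only; others in the source may bear on it.

Measured so far in an assay on Cerebral cortex for binding affinity to adenosine receptor A1 (Cavia porcellus), read by radioligand binding; on this read-out lower numbers stand for stronger inhibition and higher numbers for weaker inhibition:
compound 1 `CCCn1c(=O)n(C)c(=O)c2c1ncn2CC(N)=O` — compound 1 gives > 200000 nM, a limit of the assay.
compound 2 `CCCn1c(=O)n(C)c(=O)c2c1ncn2CCCO` — compound 2 gives 112000 nM.

For the measured compounds named here, compound 2 carries the only number in this assay. Going by the values given here, the one measured step, an at least 1.7-fold lower number from compound 1 to compound 2 (0.25 log units; that floor lies within the scatter), starts from the limit of > 200000 nM in this assay, at which 1 of the 2 values shown sits, and so gives no firm size. Compound 3 `CCCn1c(=O)n(C)c(=O)c2c1ncn2CCOC` has not been measured; it differs from compound 2 by methoxy in place of hydroxymethyl on a saturated chain carbon, two bonds along the chain from an aromatic nitrogen. Among the compounds with values here, the step from compound 1 to compound 2 is the only one bearing on this change, and it sets no direction. The step to compound 3 is expected to be a 1.2-fold higher number from compound 2 to compound 3 (0.06 log units; within the scatter), within the scatter in either direction. Compound 3 is therefore estimated at 130000 nM in this assay, between 50000 nM and 300000 nM.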

Compound 3, inhibition constant: 12400 nM
Estimate against measurement, compound 3: 10-fold (1.02 log units) above; measured number below the stated range.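

In this assay, for the compounds shown here, rearranging the same atoms from hydroxymethyl to methoxy gives a 9.0-fold lower number from compound 2 to compound 3 (0.96 log units; beyond the scatter), the first step at this position with a firm size and one beyond the scatter. Hydroxymethyl carries a hydrogen-bond donor and methoxy none, though the compounds shown cannot separate that difference from the changed place of the oxygen. Compound 1 stands at a limit of the assay, so an at least 16-fold lower number from compound 1 to compound 3 (1.20 log units; beyond the scatter) gives only a floor: the limit of > 200000 nM in this assay, at which 1 of the 3 values shown sits.

Still open, on these data alone, is whether an ethoxy group or a longer ether chain would lower the number further. An amine at the chain end is equally untested here.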